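A few compounds are considered here, and "the series" means these few. Any claim that something is new, unique, unknown or untested is made for them only; others in the source may bear on it.

Measured so far:
compound 1 `CCc1nn2c(-c3ccc(OC)cc3Cl)cccc2c1N(CC1CC1)CC1CC1`: 10 nM
compound 2 `CCCN(CCC)c1c(CC)nn2c(-c3ccc(OC)cc3Cl)cccc12`: 15 nM

Both numbers come from an assay on HEK293 cells for displacement of a labelled ligand from corticotropin-releasing factor receptor 1 (Homo sapiens), read by scintillation counting, with a stated time of 2 h; on this read-out higher numbers stand for weaker inhibition and lower numbers for stronger inhibition. Compound 1 stands at the lowest of the two numbers; the nearest is compound 2, and the step of a 1.5-fold higher number from compound 1 to compound 2 (0.18 log units; within the scatter) lies within the scatter, so the two compounds are not told apart. That step exchanges the amine and says nothing about the aryl group.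

Compound 3 `CCc1nn2c(-c3c(C)cc(OC)cc3C)cccc2c1N(CC1CC1)CC1CC1` is not yet measured. It differs from compound 1 in one place: 4-methoxy-2,6-dimethylphenyl in place of 2-chloro-4-methoxyphenyl on an aromatic carbon. Among the measured compounds shown here, no measured pair changes this aryl group, so no step in the set bears directly on the change; the single measured step, a 1.5-fold higher number from compound 1 to compound 2 (0.18 log units; within the scatter), concerns the amine and gives no guide here. With the core and the bis(cyclopropylmethyl)amino group kept as in compound 1, and a methoxy group present in both the leaving and the entering aryl group, the expectation is a number close to that of compound 1, with a broad range to allow for the untested change. The step of a 1.2-fold higher number from compound 1 to compound 3 (0.08 log units; within the scatter) is expected to stay within the scatter. For compound 3 the estimate in this assay is 12 nM, with a range from 4 nM to 40 nM.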

Compound 3, half-maximal inhibitory concentration: 13 nM
Estimate against measurement, compound 3: 1.1-fold (0.03 log units) below; low and high end bracket the measured number.
By their numbers in this assay, from the lowest: compounds 1, 3 and 2 (each within the scatter of the next).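

At the aromatic carbon next to the ring nitrogen, 4-methoxy-2,6-dimethylphenyl in place of 2-chloro-4-methoxyphenyl gives in this assay a 1.3-fold higher number from compound 1 to compound 3 (0.11 log units; within the scatter) and so does not tell the two aryl groups apart on this read-out. Among the compounds shown here, this is the first measured change at this position, since the earlier step concerned only the amine, and it shows that, with the bis(cyclopropylmethyl)amino group and the shared core held constant, the chlorine can give way to two methyl groups without a step beyond the scatter. Nothing at hand bears on why the two aryl groups read alike.

Going by these compounds, both aryl groups carry the 4-methoxy group, so its part in these numbers remains open, as does the outcome with an unsubstituted phenyl, a 2,4-dichlorophenyl or a pyridyl group at this position. Also open, on these data alone, is whether the 4-methoxy-2,6-dimethylphenyl group would read the same alongside the dipropylamino group, or alongside a different amine such as morpholine, since the aryl change has been read with one amine only.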